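Changing the acyl chain on compound 3

A few compounds are considered here, and "the series" means these few. Any claim that something is new, unique, unknown or untested is made for them only; others in the source may bear on it.

In a functional assay on MCF7 cells (Homo sapiens) for antiproliferative activity, read by MTT assay, with a stated time of 72 h (on this read-out higher numbers stand for weaker inhibition and lower numbers for stronger inhibition), compound 3 (`CC(C)=CC(=O)Nc1cc2c(N3CCCc4ccccc43)ncnc2cc1O[C@@H]1CCOC1`) gives 11100 nM, within the scatter of compound 1 (`COc1cc2ncnc(N3CCCc4ccccc43)c2cc1NC(=O)C=C(C)C`) at 6870 nM. Compound 2 (`CC/C=C/C(=O)Nc1cc2c(N3CCCc4ccccc43)ncnc2cc1OC`) gives 2870 nM, the lowest number of the three and clear of the scatter from both others. Compound 4 (`CC/C=C/C(=O)Nc1cc2c(N3CCCc4ccccc43)ncnc2cc1O[C@@H]1CCOC1`) differs from compound 3 by but-1-en-1-yl in place of 2-methylprop-1-en-1-yl on a carbonyl carbon, with but-1-en-1-yl in place of 2-methylprop-1-en-1-yl on a carbonyl carbon. The same exchange, made with methyl on the oxygen, gave a 2.4-fold lower number from compound 1 to compound 2 (0.38 log units; beyond the scatter), a modest step. Replacing that methyl with oxolan-3-yl gave a 1.6-fold higher number from compound 1 to compound 3 (0.21 log units; within the scatter), which stays within the scatter. On this single precedent, the expected step in this assay is a 2.3-fold lower number from compound 3 to compound 4 (0.36 log units; beyond the scatter). Compound 4 is estimated at 4800 nM, with an expected range of 2200 nM to 10000 nM.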

Compound 4, half-maximal inhibitory concentration: 14400 nM
Estimate against measurement, compound 4: 3.0-fold (0.48 log units) below; measured number outside the range, above it.
By their numbers in this assay, from the lowest: compound 2; then compounds 1, 3 and 4 (each within the scatter of the next, the first and the last beyond it).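

With oxolan-3-yl on the oxygen, but-1-en-1-yl in place of 2-methylprop-1-en-1-yl gives a 1.3-fold higher number from compound 3 to compound 4 (0.11 log units; within the scatter), so the step seen with methyl on the oxygen does not carry over: the same change on two cores in this assay, a 2.4-fold lower number (0.38 log units; beyond the scatter) from compound 1 to compound 2 and a 1.3-fold higher number (0.11 log units; within the scatter) from compound 3 to compound 4, 3.1-fold (0.49 log units) apart, beyond the scatter of two such steps Oxolan-3-yl in place of methyl in turn gives a 5.0-fold higher number from compound 2 to compound 4 (0.70 log units; beyond the scatter) with the but-1-en-1-yl chain, so its step depends on the group on the carbonyl carbon: the same change on two cores in this assay, a 1.6-fold higher number (0.21 log units; within the scatter) from compound 1 to compound 3 and a 5.0-fold higher number (0.70 log units; beyond the scatter) from compound 2 to compound 4, 3.1-fold (0.49 log units) apart, beyond the scatter of two such steps The two changes therefore do not add up in this assay.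

The compounds shown do not tell why the two places are coupled. On these data alone, it also remains open how an acyl chain carrying an amine, or ethyl on the oxygen, would behave.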